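Adding an acetyl group to a weak adenosine receptor agonist

The compounds below may be only part of what the source reports. "The series", "measured", "known", "first", "only" and "open" are said of these compounds alone.

The shared core of compound 1 `CCOC(=O)c1c(-c2cccc(C(F)(F)F)c2)csc1N` carries an ethyl ester, an amine and a trifluoromethylphenyl group. In a functional assay on CHO-K1 cells for agonist activity at adenosine receptor A1 (Homo sapiens), read by GTPgammaS binding (on this read-out higher numbers stand for an effect only at larger amounts of compound and lower numbers for an effect already at smaller amounts), compound 1 gives 9.4 uM. Compound 3 `CCOC(=O)c1c(N)sc(-c2ccccc2)c1-c1cccc(C(F)(F)F)c1` adds a phenyl group on an aromatic carbon of that core. In this assay compound 3 gives only > 10 uM, which is a limit of the assay and not a number. The step of an at least 1.0-fold higher number from compound 1 to compound 3 (0.02 log units; that floor lies within the scatter) is therefore known only as a floor. Compound 2 `CC(=O)c1cccc(-c2sc(N)c(C(=O)c3ccccc3)c2-c2cccc(C(F)(F)F)c2)c1`, which carries a benzoyl group in place of the ester together with a 3-acetylphenyl group, gives only > 10 uM in this assay, again a limit of the assay. Compound 4 `CCOC(=O)c1c(N)sc(-c2cccc(C(C)=O)c2)c1-c1cccc(C(F)(F)F)c1` differs from compound 3 by acetyl in place of hydrogen on an aromatic carbon. Because two of the three values sit at the limit of > 10 uM in this assay, at which 2 of the 3 values shown sit, the measured steps give no direction for this change. Compound 4 is therefore expected to remain near that limit, with the step that the limit leaves unreadable from compound 3 to compound 4 estimated to lie within the scatter. The value of compound 4 in this assay is estimated at 15 uM, with a likely range from 5 uM to 50 uM.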

Compound 4, concentration for half-maximal effect: > 10 uM
Compound 4: only a limit was reported; the forecaster's own chance of this, stated with the estimate: 70%; the middle value does not contradict the limit.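

With an acetyl group on the added phenyl ring, the result at this position in this assay is still a limit of the assay and not a number, for compound 4 as for compound 3. Measured against the hydrogen of compound 1, 3-acetylphenyl on the aromatic carbon gives an at least 1.0-fold higher number from compound 1 to compound 4 (0.02 log units; that floor lies within the scatter), so the change is known only as a floor. The steps to compound 4 from compound 3 and from compound 2 cannot be read, because both ends of each step are limits: the limit of > 10 uM in this assay, at which 3 of the 4 values shown sit.

From the compounds shown here alone, how far the acetyl group moves the value, and in which direction, stays open, since compound 3 and compound 4 have no readable number to compare. Also open, going by these compounds, is whether another group on the same phenyl ring, such as an amine or a carboxylic acid, would give a readable value.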